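Isopropyl for Phenyl on the Amide Nitrogen of Compound 2

The source may hold more compounds than are shown below. What is called first, only, known or untested is meant among the compounds shown, and "the series" means these compounds.

Compound 2 `CN(Cc1ccc(C(F)(F)F)cc1)c1cc(C(=O)Nc2ccccc2)ncn1` carries a phenyl on its amide-type nitrogen. In a physicochemical assay for solubility, using the shake flask method, measured as kinetic solubility, with a stated time of 2 h, at pH 7.4 (on this read-out lower numbers stand for lower solubility and higher numbers for higher solubility), compound 2 gives < 5000 nM, which is a limit of the assay and not a number. Its neighbour compound 1 `CN(Cc1ccc(Cl)cc1)c1cc(C(=O)Nc2ccccc2)ncn1` differs from it by chloro in place of trifluoromethyl on an aromatic carbon. In this assay compound 1 gives < 5000 nM, again a limit. The step that the two limits leave unreadable from compound 1 to compound 2 cannot be sized, since the limit of < 5000 nM in this assay, at which 2 of the 2 values shown sit, marks where both values sit.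

Among the measured compounds shown here, the next compound is compound 3 `CC(C)NC(=O)c1cc(N(C)Cc2ccc(C(F)(F)F)cc2)ncn1`. isopropyl in place of phenyl on an amide-type nitrogen The only measured step, the one from compound 1 to compound 2, changed a group on an aromatic carbon and left the amide-type nitrogen untouched, and its size is unreadable in any case. For the measured compounds named here, no measured step therefore bears on the exchange at the amide-type nitrogen, and neither a direction nor a size beyond the scatter can be drawn from the numbers. For compound 3 the solubility in this assay is estimated at 5000 nM, with a range from 1000 nM to 30000 nM. The expected step is a number no lower from compound 2 to compound 3 (the limit leaves the size open).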

Compound 3, solubility: 13000 nM
For compound 3 the middle estimate is 2.6-fold (0.41 log units) below the measured one; measured number inside the range.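

In this assay, among the compounds shown here, the exchange on the amide-type nitrogen gives the first step that can be read, an at least 2.6-fold higher number from compound 2 to compound 3 (0.41 log units; beyond the scatter). Compound 3 is also the only compound shown whose value is a number and not a limit, so the amide-type nitrogen is the one place where the effect of a change on this read-out can be sized, while the step between chloro and trifluoromethyl on the aromatic carbon cannot be read. Even here the size is only a lower bound, and the true distance from phenyl to isopropyl could be larger, as compound 2 stands at a limit: the limit of < 5000 nM in this assay, at which 2 of the 3 values shown sit.

From the compounds shown here alone, a single exchange cannot separate the loss of the aromatic ring from the drop in heavy atoms, and it remains open whether cyclohexyl, which would keep a six-membered ring without the aromatic one, or a chain carrying an amine on the same nitrogen would read closer to phenyl or to isopropyl. Going by these compounds, it is also open whether isopropyl in place of phenyl would give a step of similar size with chloro in place of trifluoromethyl on the aromatic carbon.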